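Chloro added to the phenyl of compound 2

A few compounds are considered here, and "the series" means these few. Any claim that something is new, unique, unknown or untested is made for them only; others in the source may bear on it.

Values in a functional assay on PC-3 cells (Homo sapiens) for inhibition, read by sulforhodamine B assay, with a stated time of 48 h (a lower number here means a stronger inhibitor of growth, a higher number a weaker inhibitor of growth), are as follows
compound 1 `CCOC(=O)c1nn(-c2ccc(Cl)cc2)c(-c2ccc(F)cc2)c1CNC(C)(C)C` gives 405000 nM; > 537000 nM (2 entries)
compound 2 `CC(C)(C)NCc1c(C(=O)O)nn(-c2ccccc2)c1-c1ccc(F)cc1` gives > 680000 nM
compound 3 `CC(C)(C)NCc1c(C(=O)O)nn(-c2ccccc2)c1-c1ccccc1` gives > 716000 nM
compound 4 `CC(C)(C)NCc1c(C(=O)O)nn(-c2ccc(Cl)cc2)c1-c1ccc(F)cc1` is not yet measured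

Compound 2 stands at > 680000 nM as a limit and not a number. Compound 3 stands at > 716000 nM and this too is a limit. Within the data shown here, the one measured step is a step that the two limits leave unreadable from compound 2 to compound 3 and it offers no size to carry over.

Compound 4 differs from compound 2 by chloro in place of hydrogen on an aromatic carbon in a change of phenyl to 4-chlorophenyl, with chloro in place of hydrogen on an aromatic carbon, para to a large group. The nearest guide is compound 1 with 405000 nM; > 537000 nM (2 entries) as its entries, and it also carries the 4-chlorophenyl.

Among the measured compounds shown here, no measured step gives a size or direction for this change, so no step beyond the scatter is expected in this assay and growth inhibition is expected to stay weak. A report as a limit is the likely outcome. The expected outcome is an at least 1.2-fold lower number from compound 2 to compound 4 (0.09 log units; that floor lies within the scatter) on this reading. For compound 4 the estimate is 550000 nM with an expected range of 250000 nM to 800000 nM in this series.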

Compound 4, concentration for 50% growth inhibition: > 623000 nM
Compound 4: only a limit was reported; the forecaster's own chance of this, stated with the estimate: 70%; at least 1.1-fold (0.05 log units) between middle value and limit.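

In this assay compound 4 gives > 623000 nM as a limit. Compound 2 gives > 680000 nM as a limit too, so no step can be read between compound 2 and compound 4. The compounds shown leave open whether chloro in place of hydrogen on this aromatic carbon changes growth inhibition at all, and in which direction.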